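The compounds below may be only part of what the source reports. "The series", "measured", "known", "first", "only" and "open" are said of these compounds alone.

Compound 1 `COc1cc(C=C(C(=O)/C=C/c2cccc(OC)c2OC)C(=O)/C=C/c2cccc(OC)c2OC)cc(Br)c1O` and compound 2 `COc1cc(C=C(C(=O)/C=C/c2cccc(OC)c2OC)C(=O)/C=C/c2cccc(OC)c2OC)cc(OC)c1O` share one core, while compound 3 `COc1cc(OC)c(/C=C/C(=O)C(=Cc2cc(Br)c(O)c(OC)c2)C(=O)/C=C/c2c(OC)cc(OC)cc2OC)c(OC)c1` and compound 4 `COc1cc(OC)c(/C=C/C(=O)C(=Cc2cc(OC)c(O)c(OC)c2)C(=O)/C=C/c2c(OC)cc(OC)cc2OC)c(OC)c1` share another; the difference between the two cores is not broken down here. In a functional assay on CNE-2 cells (Homo sapiens) for antiproliferative activity, read by sulforhodamine B assay, with a stated time of 48 h (on this read-out higher numbers stand for weaker inhibition and lower numbers for stronger inhibition), compound 1 gives 220 nM, compound 2 gives 300 nM and compound 3 gives 1320 nM. Within the data shown here, the single change from compound 1 to compound 2 is methoxy in place of bromo on an aromatic carbon, and it made a 1.4-fold higher number from compound 1 to compound 2 (0.13 log units; within the scatter). The same change, at the same place around the ring, is methoxy in place of bromo on an aromatic carbon, leading from compound 3 to compound 4. Resting on the step of a 1.4-fold higher number from compound 1 to compound 2 (0.13 log units; within the scatter), which stayed within the scatter, a step of similar size is expected, a 1.4-fold higher number from compound 3 to compound 4 (0.13 log units; within the scatter). Compound 4 is therefore estimated at 1800 nM, most likely between 900 nM and 3600 nM.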

Compound 4, half-maximal inhibitory concentration: 680 nM
Beside the measured number, compound 4's estimate is 2.6-fold (0.42 log units) above it; measured number below the stated range.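

In this assay, putting methoxy in place of bromo on the second core gives a 1.9-fold lower number from compound 3 to compound 4 (0.29 log units; within the scatter). Set beside the earlier step, this one shows no real difference between the two cores: the same change on two cores in this assay, a 1.4-fold higher number (0.13 log units; within the scatter) from compound 1 to compound 2 and a 1.9-fold lower number (0.29 log units; within the scatter) from compound 3 to compound 4, 2.6-fold (0.42 log units) apart, within the scatter of two such steps. On these two cores, then, the change stays within the scatter, which shows that it can be carried from one to the other, but two pairs cannot show that it would behave the same way on any further core.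

The compounds shown leave open what other groups at this place on the 4-hydroxy-3,5-dimethoxyphenyl ring would do, such as an amine, a carboxylic acid or a longer chain. They also leave open whether a change of this kind would stay as small on a third core.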